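Replacing acetyl with dimethylamino: expected change in cytotoxicity

This account rests on a few compounds, and the source may have more. Where it says the series, first, only, none or still open, it means among the compounds named here.

Measured so far:
compound 1 `COc1cc(C)cc(-c2c(-c3ccnc(-c4ccc(C(C)=O)cc4)c3)cnn2CC#N)c1` — in a functional assay on UO-31 cells (Homo sapiens) for cytotoxicity, read by sulforhodamine B assay, with a stated time of 48 h, tested at 1 uM (on this read-out lower numbers stand for a stronger effect and higher numbers for a weaker effect at the one concentration tested), compound 1 gives 11%
compound 2 `COc1cc(C)cc(-c2nn(CC#N)cc2-c2ccc(-c3cccc(C(C)=O)c3)nc2)c1` — in this assay compound 2 gives 21%

Two compounds of the series have numbers in this assay. Compound 1 has the lower of the two, but the gap to compound 2 lies within the usual scatter, so the two read as the same and neither can be called the more effective one. For the measured compounds named here, no pair differing in one place has been measured, so no step size is known yet.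

Compound 3 `COc1cc(C)cc(-c2c(-c3ccnc(-c4ccc(N(C)C)cc4)c3)cnn2CC#N)c1` is the next compound to be measured in this assay. It differs from compound 1 in one place: dimethylamino in place of acetyl on an aromatic carbon. The group leaves on the six-membered aromatic ring of carbon only, para to a large group, and the dimethylamino group enters at the same aromatic carbon.

Going by the values given here, with no measured step to lean on, the size of the change is open. The expectation is a moderate move toward higher numbers in this assay, that is a weaker effect, with the step from compound 1 to compound 3 expected as a number 21 percentage points higher from compound 1 to compound 3 (beyond the scatter). Compound 3 is therefore expected to give 32%, within a range from 8% to 70%.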

Compound 3, a percentage reported as activity, at one concentration (the size of the read-out at that concentration, not a potency): 12%
Estimate against measurement, compound 3: 20 percentage points above; the range from low to high includes it.
By their numbers in this assay, from the lowest: compounds 1, 3 and 2 (each within the scatter of the next).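

In this assay, for the compounds shown here, dimethylamino in place of acetyl on the aromatic carbon gives a number 1 percentage points higher from compound 1 to compound 3 (within the scatter), the first measured step that differs in one place. At this position and at the one concentration tested, 4-(dimethylamino)phenyl therefore reads the same as 4-acetylphenyl, so the carbonyl of the acetyl group is not needed to hold the read-out in this pair. No supporting measurement bears on why the two groups read alike.

From the compounds shown here alone, whether this tolerance extends to other groups at the same carbon, such as a carboxylic acid, a primary amine or a longer chain ending in an amine, remains open. Also open, going by these compounds, is whether compound 1 and compound 3 would still read alike at other concentrations, since a single-concentration read-out is not a potency.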